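The compounds below may be only part of what the source reports. "The series", "measured", "known", "first", "only" and "open" are said of these compounds alone.

Compound 1 `COc1ccc(-c2nc3ccc[nH]c-3n2)c(OC)c1` and compound 2 `COc1cc(S(C)(=O)=O)ccc1-c1nc2ccc[nH]c-2n1` share one core and differ in a single group. In a functional assay on the whole organism with Canis familiaris (Canis lupus familiaris) as the target (a higher number here means that more compound is needed for the effect, a lower number that less compound is needed), compound 2 gives 0.4 mg/kg, and compound 1 gives 0.8 mg/kg; the step of a 2.0-fold higher number from compound 2 to compound 1 (0.30 log units; within the scatter) goes with the change (methoxy in place of methylsulfonyl on an aromatic carbon). Compound 3 `CS(=O)(=O)c1ccc(-c2nc3cc[nH]cc-3n2)cc1` is built on another core; how the two cores differ is not broken down here. In this assay compound 3 gives 7.5 mg/kg, the highest of the three numbers. Compound 4 `COc1ccc(-c2nc3cc[nH]cc-3n2)cc1` is not yet measured and differs from compound 3 by methoxy in place of methylsulfonyl on an aromatic carbon, the same kind of change as before, though in the earlier pair the group also sat meta to a methoxy group. Since the earlier step of a 2.0-fold higher number from compound 2 to compound 1 (0.30 log units; within the scatter) lay within the scatter, a step of similar size, a 1.6-fold higher number from compound 3 to compound 4 (0.20 log units; within the scatter), is expected here too. Compound 4 is therefore estimated at 12 mg/kg, with a likely range from 5 mg/kg to 30 mg/kg.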

Compound 4, dose for half-maximal effect: 1.7 mg/kg
Compound 4: middle estimate off by 7.1-fold (0.85 log units), on the high side, and the stated range ends above it.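

In this assay the change from methylsulfonyl to methoxy goes with a 4.4-fold lower number from compound 3 to compound 4 (0.64 log units; beyond the scatter) and so less compound is needed for the effect on this core. The same change does not carry over from one core to the other as a fixed step: the same change on two cores in this assay, a 2.0-fold higher number (0.30 log units; within the scatter) from compound 2 to compound 1 and a 4.4-fold lower number (0.64 log units; beyond the scatter) from compound 3 to compound 4, 8.8-fold (0.95 log units) apart, beyond the scatter of two such steps. This shows that the size of the step on one core is a poor guide to its size on the other, but two pairs cannot show what sets the difference, and the earlier pair also carries a further methoxy group.

On these data alone, how another group in this place, such as an amine or a carboxylic acid, would fare on the two cores stays open. As far as these compounds go, whether any such step would transfer between them also remains unknown.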